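Bromo in place of chloro on compound 1

This account rests on a few compounds, and the source may have more. Where it says the series, first, only, none or still open, it means among the compounds named here.

Going by the values given here, in a functional assay on the whole organism for antagonist activity, with Mus musculus as the target (on this read-out lower numbers stand for an effect already at smaller amounts and higher numbers for an effect only at larger amounts of compound), compound 1 (`CCC(=O)N(c1ccc(Cl)cc1)C1CCCC1N(C)C`) gives 0.2 mg/kg as the lowest of the two actual numbers so far. Compound 3 (`CCC(=O)N(c1ccc(Cl)c(C)c1)C1CCCC1N(C)C`) gives 2 mg/kg as the other number. Compound 2 (`CN(C)C1CCCC1N(C=O)c1ccccc1`) reads > 50 mg/kg as a limit and not a number. Compound 4 (`CCC(=O)N(c1ccc(Br)cc1)C1CCCC1N(C)C`) differs from compound 1 in one place (bromo in place of chloro on an aromatic carbon) on an aromatic carbon para to a large group. Among the compounds with values here, the only measured step is a 10-fold higher number from compound 1 to compound 3 (1.00 log units; beyond the scatter) for a methyl in place of hydrogen on an aromatic carbon. That change adds a group, whereas this one exchanges one group for another, so no step beyond the scatter is expected in this assay here. The expected step is a 1.5-fold higher number from compound 1 to compound 4 (0.18 log units; within the scatter) on this reasoning. Compound 4 is estimated at 0.3 mg/kg with an expected range from 0.08 mg/kg to 1 mg/kg for now.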

Compound 4, dose for half-maximal effect: 3 mg/kg
Compound 4: middle estimate off by 10-fold (1.00 log units), on the low side, and the stated range ends below it.
By their numbers in this assay, from the lowest: compound 1; then compounds 3 and 4 (each within the scatter of the next). At a limit, above all of these: compound 2.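

In this assay, the aromatic carbon para to a large group proves sensitive to a swap of chloro for bromo, which gives a 15-fold higher number from compound 1 to compound 4 (1.18 log units; beyond the scatter) even though the counts of heavy atoms, hydrogen-bond donors and hydrogen-bond acceptors stay the same. Earlier, only an added methyl had shown a step beyond the scatter, whereas here exchanging one group for another does so too. Nothing shown here accounts for this step. Going by these compounds, whether fluoro or methoxy at this same carbon would keep a number as low as that of compound 1 remains open.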